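A pyridinyl group in place of methylsulfanyl on compound 3

The compounds below may be only part of what the source reports. "The series", "measured", "known", "first", "only" and "open" are said of these compounds alone.

Compound 3 `CSc1cnc(C(=O)CCCCCCc2ccccc2)o1` gives only a limit in an assay on HEK-293T cells for inhibition of diacylglycerol lipase-alpha (Homo sapiens), read by colorimetric assay (on this read-out higher numbers stand for weaker inhibition and lower numbers for stronger inhibition), namely > 10000 nM. Compound 1 `Cc1coc(C(=O)CCCCCCc2ccccc2)n1` likewise rests at a limit, > 10000 nM. Compound 2 `O=C(CCCCCCc1ccccc1)c1ncc(C(=O)C(F)(F)F)o1` gives 1820 nM in this assay. The step that the two limits leave unreadable from compound 1 to compound 3 is therefore unreadable, whereas an at least 5.4-fold higher number from compound 2 to compound 3 (0.73 log units; beyond the scatter) marks a loss of at least modest size; two of the three values sit at the limit of > 10000 nM in this assay, at which 2 of the 3 values shown sit. Compound 4 `Cc1ccc(-c2cnc(C(=O)CCCCCCc3ccccc3)o2)nc1` differs from compound 3 by 5-methylpyridin-2-yl in place of methylsulfanyl on an aromatic carbon. Going by the values given here, no measured step tests an aromatic group at this position, and neither compound 1 nor compound 3 reaches a readable number. Compound 4 is therefore expected to stay weak, with an estimated 9000 nM between 2500 nM and 30000 nM. The expected step of an at least 1.1-fold lower number from compound 3 to compound 4 (0.04 log units; that floor lies within the scatter) may well end at the limit again.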

Compound 4, half-maximal inhibitory concentration: > 10000 nM
Compound 4 was reported as a limit; the forecaster's own chance of this, stated with the estimate: 55%; middle value at least 1.1-fold (0.04 log units) away from the limit.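

In this assay, an aromatic ring on this carbon, next to the ring oxygen, gives no more of a readable number than methylsulfanyl did: the limit of > 10000 nM in this assay, at which 3 of the 4 values shown sit. The step between these two groups cannot be read, since both values are limits. Replacing (trifluoromethyl)carbonyl gives an at least 5.4-fold higher number from compound 2 to compound 4 (0.73 log units; beyond the scatter), so among the three groups shown at this position, only that one gives a readable number.

As far as these compounds go, whether a nitrile or a methyl ester at this position would give a readable number remains open. So does any real difference between methylsulfanyl and 5-methylpyridin-2-yl.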